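The source may hold more compounds than are shown below. What is called first, only, known or untested is meant among the compounds shown, and "the series" means these compounds.

Measured compounds:
compound 1 `O=c1oc(Nc2ccccc2I)nc2ccccc12` — 3500 nM
compound 2 `O=c1oc(Nc2ccccc2I)nc2cc(Cl)ccc12` — 700 nM

Of the compounds shown here, two have been tested in an assay on isolated protein for inhibition of complement C1r subcomponent (Homo sapiens); on this read-out lower numbers stand for stronger inhibition and higher numbers for weaker inhibition. Compound 1 gives 3500 nM. For the measured compounds named here, compound 2 gives 700 nM, the lowest of the two numbers, and its only neighbour is compound 1, which sits well above it. Going by the values given here, the single measured step is a 5.0-fold lower number from compound 1 to compound 2 (0.70 log units; beyond the scatter), where chloro replaced hydrogen on an aromatic carbon of the shared core.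

Compound 3 `Cc1ccc2c(=O)oc(Nc3ccccc3I)nc2c1` has not been measured. It differs from compound 2 in one place: methyl in place of chloro on an aromatic carbon. Among the compounds with values here, the one measured step bears on this only indirectly: it shows that filling this position with chloro rather than leaving it as hydrogen gives a modest gain. Whether methyl behaves like chloro or like hydrogen at the same place is not shown by any pair here. A cautious expectation is that compound 3 lands between the two measured numbers, so the step is expected to be a 2.1-fold higher number from compound 2 to compound 3 (0.33 log units; beyond the scatter), a modest rise. The estimated value for compound 3 in this assay is 1500 nM, with a range from 600 nM to 4000 nM.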

Compound 3, half-maximal inhibitory concentration: 800 nM
The estimate for compound 3 lay 1.9-fold (0.27 log units) above the measured number; low and high end bracket the measured number.
By their numbers in this assay, from the lowest: compounds 2 and 3 (each within the scatter of the next); then compound 1.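

In this assay, the exchange of chloro for methyl on this aromatic carbon gives a 1.1-fold higher number from compound 2 to compound 3 (0.06 log units; within the scatter) and so leaves compound 2 and compound 3 indistinguishable in this assay. Methyl in place of hydrogen on the same carbon gives a 4.4-fold lower number from compound 1 to compound 3 (0.64 log units; beyond the scatter) and is therefore a real step, so the gain seen earlier is not unique to chloro: two different groups at this place both separate from hydrogen, and by a similar amount. Nothing measured here offers an explanation for why methyl and chloro match at this position.

From the compounds shown here alone, two small groups agreeing says little about how much else this position would accept, so it remains open whether an ethyl group, a longer chain, an amine or a carboxylic acid on this carbon would keep the number as low as in compound 2 and compound 3 or would lose the gain. The compounds shown also leave open whether chloro or methyl would give a similar step on any other aromatic carbon of the shared core.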